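The compounds below may be only part of what the source reports. "The series", "measured", "known", "first", "only" and "open" are said of these compounds alone.

Three compounds in this series share one core and differ only in the aryl group attached to a nitrogen on that core. Compound 1 `COc1ccccc1Nc1nc(SCc2ccc(C(F)(F)F)cc2)nc2ccccc12` carries a 2-methoxyphenyl there. In a functional assay on HGC-27 cells (Homo sapiens) for cytotoxicity, read by MTT assay, with a stated time of 72 h (on this read-out higher numbers stand for weaker inhibition and lower numbers for stronger inhibition), compound 1 gives only a limit, > 50000 nM, not a number. Compound 2 `FC(F)(F)c1ccc(CSc2nc(Nc3cccc(C(F)(F)F)c3)c3ccccc3n2)cc1` carries a 3-(trifluoromethyl)phenyl, and in this assay compound 2 gives 11700 nM. Compound 3 `FC(F)(F)c1ccc(CSc2nc(Nc3ccc(C(F)(F)F)cc3)c3ccccc3n2)cc1` carries a 4-(trifluoromethyl)phenyl, and in this assay compound 3 gives 7560 nM. The change an at least 4.2-fold lower number from compound 1 to compound 2 (0.63 log units; beyond the scatter) and the change an at least 6.6-fold lower number from compound 1 to compound 3 (0.82 log units; beyond the scatter) are both beyond the scatter, while a 1.5-fold lower number from compound 2 to compound 3 (0.19 log units; within the scatter) is within it (the limit of > 50000 nM in this assay, at which 1 of the 3 values shown sits). Compound 3 thus holds the lowest of the two numbers, with compound 2 within the scatter of it.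

Compound 4 `Fc1ccc(Nc2nc(SCc3ccc(C(F)(F)F)cc3)nc3ccccc23)cc1Cl` differs from compound 3 by 3-chloro-4-fluorophenyl in place of 4-(trifluoromethyl)phenyl on a nitrogen on an aromatic ring. For the measured compounds named here, no measured step swaps a trifluoromethyl for a chloro and a fluoro; the only step on this ring that keeps a trifluoromethyl, from compound 2 to compound 3, was within the scatter, and the larger steps from compound 1 involved a 2-methoxyphenyl. The step of a 1.2-fold higher number from compound 3 to compound 4 (0.08 log units; within the scatter) is therefore expected to be small, likely not beyond the scatter. Compound 4 is estimated at 9000 nM, between 3000 nM and 27000 nM.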

Compound 4, half-maximal inhibitory concentration: 14700 nM
Compound 4: the middle estimate sits 1.6-fold (0.21 log units) below what was measured; low and high end bracket the measured number.
By their numbers in this assay, from the lowest: compounds 3, 2 and 4 (each within the scatter of the next). At a limit, above all of these: compound 1.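

In this assay, a 3-chloro-4-fluorophenyl on this nitrogen carries no trifluoromethyl, yet neither comparison with a trifluoromethyl-bearing ring leaves the scatter: a 1.9-fold higher number from compound 3 to compound 4 (0.29 log units; within the scatter) and a 1.3-fold higher number from compound 2 to compound 4 (0.10 log units; within the scatter). Among compounds 2, 3 and 4, then, the three aryl groups cannot be told apart, whereas the new group, like the other two, separates from the 2-methoxyphenyl of compound 1: an at least 3.4-fold lower number from compound 1 to compound 4 (0.53 log units; beyond the scatter). The true size of that step stays unknown, as compound 1 gives only a limit and not a number: the limit of > 50000 nM in this assay, at which 1 of the 4 values shown sits.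

From the compounds shown here alone, whether the methoxy group itself or its place on the ring sets compound 1 apart remains open. Also open, going by these compounds, is how this position would respond to an aryl group bearing an amine or a carboxylic acid, or to a plain alkyl chain in place of the aryl group.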